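Returning an Aromatic Group to the Ring Amine Nitrogen

A few compounds are considered here, and "the series" means these few. Any claim that something is new, unique, unknown or untested is made for them only; others in the source may bear on it.

Compound 1 `Nc1scc(CN2CCN(c3cccc(Cl)c3Cl)CC2)c1C(=O)c1ccc(Cl)cc1`: -77%
Compound 2 `Nc1scc(CN2CCN(c3cccc(C(F)(F)F)c3)CC2)c1C(=O)c1ccc(Cl)cc1`: -80%
Compound 3 `Nc1scc(CN2CCN(C3CCCCCC3)CC2)c1C(=O)c1ccc(Cl)cc1`: -25%

In a functional assay on CHO cells with adenosine receptor A1 (Homo sapiens) as the target, read by cAMP accumulation and immunoassay, with a stated time of 6 min, tested at 10 uM (a lower number here means a stronger effect, a higher number a weaker effect of the compound at the concentration tested), compound 3 has the highest number of the three, meaning the weakest effect. Among the measured compounds shown here, two steps bear on what follows: a number 52 percentage points higher from compound 1 to compound 3 (beyond the scatter) and a number 55 percentage points higher from compound 2 to compound 3 (beyond the scatter) both show that putting cycloheptyl on the ring amine nitrogen in place of an aromatic group raised the number sharply, whereas a number 3 percentage points lower from compound 1 to compound 2 (within the scatter) shows two aromatic groups giving numbers within the scatter. Compound 4 `Nc1scc(CN2CCN(c3c(F)cccc3F)CC2)c1C(=O)c1ccc(Cl)cc1` reverses that move: 2,6-difluorophenyl in place of cycloheptyl on an amine nitrogen in a ring. With an aromatic group back in place, the step of a number 45 percentage points lower from compound 3 to compound 4 (beyond the scatter) is expected, undoing most of a number 52 percentage points higher from compound 1 to compound 3 (beyond the scatter). Compound 4 is therefore estimated at -70%, within a range from -90% to -40%.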

Compound 4, a percentage reported as activity, at one concentration (the size of the read-out at that concentration, not a potency): -80%
Beside the measured number, compound 4's estimate is 10 percentage points above it, and the stated range covers the measured number.
By their numbers in this assay, from the lowest: compounds 2, 4 and 1 (each within the scatter of the next); then compound 3.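

Putting an aromatic group back on the ring amine nitrogen gives a number 55 percentage points lower from compound 3 to compound 4 (beyond the scatter) in this assay and brings the number level with the other aromatic compounds. A third substitution pattern thus fits in, with no change at the digits printed from compound 2 to compound 4 (within the scatter) and a number 3 percentage points lower from compound 1 to compound 4 (within the scatter), so in these compounds the two fluorines of 2,6-difluorophenyl serve as well as the chlorines or the trifluoromethyl group. No measurement here explains the gap between the aromatic groups and cycloheptyl.

Still open, from the compounds shown here alone, is whether an unsubstituted phenyl or a pyridine ring on this nitrogen would give a number like these.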